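The source may report more compounds than this note shows. Statements on the series, on what has been measured and on what is new or still open speak of the compounds shown alone.

Series notes. In a functional assay on MDA-MB-231 cells (Homo sapiens) for inhibition, read by sulforhodamine B assay, with a stated time of 48 h (on this read-out lower numbers stand for stronger inhibition of growth and higher numbers for weaker inhibition of growth), compound 1 `CC1CCCc2c1nc(N)c(C#N)c2-c1cccn1C` gives 69200 nM. Compound 2 `Cn1cccc1-c1cc(-c2cccs2)nc(N)c1C#N` reaches only the limit of this assay, > 100000 nM. Compound 3 `CC1CCCc2c1[nH]c(=O)c(C#N)c2-c1cccn1C` likewise sits at the limit, > 100000 nM. Going by the values given here, compound 2 therefore stands at the limit of > 100000 nM in this assay, at which 2 of the 3 values shown sit, alongside compound 3, with compound 1 holding the only numbered value. Among the compounds with values here, no two measured compounds differ in a single place, so nothing here ties one change to a shift in this assay. Compound 4 `Cn1cccc1-c1cc(-c2ccccc2)nc(N)c1C#N` differs from compound 2 by phenyl in place of thiophen-2-yl on an aromatic carbon. With compound 2 at a limit, no step beyond the scatter is expected for this change in either direction. The expected step is a number no higher from compound 2 to compound 4 (the limit leaves the size open). Compound 4 is accordingly estimated at 100000 nM, within 40000 nM to 300000 nM, most likely again reported only as a limit.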

Compound 4, concentration for 50% growth inhibition: 67600 nM
Compound 4: middle estimate off by 1.5-fold (0.17 log units), on the high side; low and high end bracket the measured number.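

At this position, next to the ring nitrogen, phenyl in place of thiophen-2-yl gives an at least 1.4-fold lower number from compound 2 to compound 4 (0.17 log units; that floor lies within the scatter). Going by these compounds alone, this is the first step that can be read, and with compound 4 at 67600 nM in this assay, a phenyl at this position yields a numbered value. The true size of the step stays open because compound 2 is a limit and not a number: the limit of > 100000 nM in this assay, at which 2 of the 4 values shown sit.

On these data alone, whether a change at this position can move the value beyond the scatter remains open. The compounds shown leave untested a phenyl bearing a methoxy group or an amine in this place.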